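Purine series: chain substituent swap from compound 2 to compound 4

A few compounds are considered here, and "the series" means these few. Any claim that something is new, unique, unknown or untested is made for them only; others in the source may bear on it.

Three members of the series have a number in a functional assay on HepG2 cells (Homo sapiens) for antiproliferative activity, read by CCK-8 assay, with a stated time of 72 h, tested at 8 uM (on this read-out higher numbers stand for a stronger effect at the one concentration tested and lower numbers for a weaker effect), so far. Compound 1 `CC(C)n1cnc2c(Nc3cccc(Cl)c3)nc(NCOCc3ccc(C(=O)Nc4ccccc4N)cc3)nc21` gives 60.5%. Compound 3 `CCCCn1cnc2c(Nc3cccc(Cl)c3)nc(NCOCc3ccc(/C=C/C(=O)Nc4ccccc4N)cc3)nc21` gives 30.4%. Compound 2 `COC(CCn1cnc2c(NCc3ccc(C(=O)Nc4ccccc4N)cc3)nc(Cl)nc21)OC` gives 34.2% in this assay, which places it second highest of the three numbers: its nearest neighbour is compound 3, whose number lies lower but within the scatter, so the two are not told apart; its furthest is compound 1, whose number lies higher by a gap beyond the scatter.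

Compound 4 `CCCCn1cnc2c(NCc3ccc(C(=O)Nc4ccccc4N)cc3)nc(Cl)nc21` has not yet been measured. It differs from compound 2 in one place: ethyl in place of dimethoxymethyl on a saturated chain carbon, two bonds along the chain from an aromatic nitrogen. Within the data shown here, no pair of measured compounds differs by this change alone, and compounds 1 and 3 differ from compound 2 in several places at once, so nothing measured speaks directly to the size or direction of this step.

Among the measured compounds shown here, with no comparable step on record, a step of no more than the usual scatter is expected from compound 2 to compound 4, in either direction, as a number 0.8 percentage points higher from compound 2 to compound 4 (within the scatter). Compound 4 is therefore estimated at 35% in this assay, within a range from 18% to 52%.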

Compound 4, a percentage reported as inhibition, at one concentration (the size of the read-out at that concentration, not a potency): 19.6%
Compound 4: middle estimate off by 15.4 percentage points, on the high side; the range from low to high includes it.
By their numbers in this assay, from the lowest: compound 4; then compounds 3 and 2 (each within the scatter of the next); then compound 1.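

In this assay, among these compounds, the change of dimethoxymethyl to ethyl gives a number 14.6 percentage points lower from compound 2 to compound 4 (beyond the scatter) and so supplies the first comparison that isolates a single place. The substituent on a saturated chain carbon, two bonds along the chain from an aromatic nitrogen, therefore affects the read-out, a point that compounds 1 and 3 could not establish since each differs from compound 2 in several places. The change removes 5 heavy atoms with 2 hydrogen-bond acceptors and introduces 2 heavy atoms with no hydrogen-bond acceptors, but no measurement on hand ties the step to any property of either group.

This one pair cannot separate the loss of the two oxygen atoms from the change in group size, so a single methoxy group, a longer chain such as hexyl, or a chain ending in an amine or a carboxylic acid at this place would each bear on that question. Going by these compounds, whether the step carries over to compounds with the other substitution seen in compounds 1 and 3 also remains open.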